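The source may report more compounds than this note shows. Statements on the series, on what has been measured and on what is new or still open speak of the compounds shown alone.

Working notes on the series, inhibition of paw edema.

Among the measured compounds shown here, compound 2 `CCOC(=O)C(=O)Nc1ccccc(NC)c1=O` stands lowest of the two numbers measured so far in a functional assay on the whole organism (strain Sprague-Dawley CD) for inhibition, with Rattus norvegicus as the target, read by paw edema, at a dose of 30 mg/kg by the oral route (on this read-out lower numbers stand for a weaker effect and higher numbers for a stronger effect at the one dose given), where compound 2 gives 0%. For the measured compounds named here, its nearest neighbour is compound 1 `CCOC(=O)C(=O)Nc1ccccc(C)c1=O`, which in this assay gives 6%; the single measured step, a number 6 percentage points lower from compound 1 to compound 2 (within the scatter), lies within the scatter, so the two numbers cannot be ordered.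

Compound 3 `CCOC(=O)C(=O)Nc1ccccc(N(C)C(=O)C(=O)OCC)c1=O` differs from compound 2 by (ethoxycarbonyl)carbonyl in place of hydrogen on a nitrogen on an aromatic ring. Going by the values given here, no measured step touches this place or this entering group; the only step in hand, a number 6 percentage points lower from compound 1 to compound 2 (within the scatter), changed a group on an aromatic carbon and was itself within the scatter. Both measured numbers sit near the floor of the read-out. On that basis the step of a number 5 percentage points higher from compound 2 to compound 3 (within the scatter) is expected to remain within the scatter, with no direction assigned. The estimate for compound 3 in this assay is 5%, ranging from 0% to 20%.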

Compound 3, a percentage reported as inhibition, in the whole organism at one dose (the size of the read-out at that dose, not a potency): 6%
Compound 3: the middle estimate sits 1 percentage points below what was measured; the range from low to high includes it.
By their numbers in this assay, from the lowest: compounds 2, 1 and 3 (each within the scatter of the next).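

In this assay, among the compounds shown here, the step of a number 6 percentage points higher from compound 2 to compound 3 (within the scatter) is the first reading at this place, the nitrogen on an aromatic ring. Bringing in (ethoxycarbonyl)carbonyl, with its 7 heavy atoms, in place of hydrogen there does not separate the two compounds at the one dose given, so no direction can be assigned to this change. Nothing in hand bears on why the read-out responds in this way.

From the compounds shown here alone, it remains open whether an acetyl group or a free carboxylic acid on this nitrogen would give a step beyond the scatter. Going by these compounds, it also remains open whether a longer chain in place of the methyl on the same nitrogen would move the read-out away from the values seen so far.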